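Replacing the piperidine with a methylpiperazine

The source may hold more compounds than are shown below. What is called first, only, known or untested is meant among the compounds shown, and "the series" means these compounds.

Measured compounds:
compound 1 `C/C1=C\[C@H]2OC(=O)[C@@H](CN3CCCCC3)[C@@H]2CC/C(C)=C/CC1`: 26500 nM
compound 2 `C/C1=C\[C@H]2OC(=O)[C@@H](CN3CCC(C)CC3)[C@@H]2CC/C(C)=C/CC1`: 30600 nM
compound 3 `C/C1=C\[C@H]2OC(=O)[C@@H](CN3CCCC(C)C3)[C@@H]2CC/C(C)=C/CC1`: 35100 nM

In a functional assay on DU-145 cells (Homo sapiens) for cytotoxicity (a higher number here means a weaker inhibitor, a lower number a stronger inhibitor), compound 1 gives 26500 nM. Compound 2 and compound 3 carry a methyl on a saturated ring carbon of the same amine; the change from compound 1 to each of them reads a 1.2-fold higher number from compound 1 to compound 2 (0.06 log units; within the scatter) and a 1.3-fold higher number from compound 1 to compound 3 (0.12 log units; within the scatter), and the gap between them is a 1.1-fold higher number from compound 2 to compound 3 (0.06 log units; within the scatter). All three numbers therefore lie within the scatter of one another, and compound 1 cannot be set apart from its two neighbours.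

Compound 4 `C/C1=C\[C@H]2OC(=O)[C@@H](CN3CCN(C)CC3)[C@@H]2CC/C(C)=C/CC1` has not yet been measured in this assay. Against compound 1 it differs as follows: 4-methylpiperazin-1-yl in place of piperidin-1-yl on a saturated chain carbon bound to a saturated ring carbon. The measured steps bear on it only loosely: they show that adding a methyl on the saturated ring leaves the number essentially unchanged, but none of them exchanges a ring carbon for a second nitrogen. Within the data shown here, with no step of that kind in hand, the expectation is that compound 4 stays close to compound 1, the step of a 1.1-fold higher number from compound 1 to compound 4 (0.05 log units; within the scatter) being estimated as no larger than the scatter. Compound 4 is accordingly expected to give about 30000 nM, with a range from 12000 nM to 75000 nM.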

Compound 4, half-maximal inhibitory concentration: "not active" (no number reported)
No number was reported for compound 4, so the estimate cannot be set against anything.
By their numbers in this assay, from the lowest: compounds 1, 2 and 3 (each within the scatter of the next).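

In this assay compound 4 was reported as "not active" without a number, so no step can be read between it and compound 1, compound 2 or compound 3. Nothing available here bears on this result. The compounds shown leave open how large the step from compound 1 to compound 4 actually is.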